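The source may hold more compounds than are shown below. What is called first, only, known or untested is meant among the compounds shown, and "the series" means these compounds.

Compound 1 (`CC(C)C[C@@H]1NC(=O)[C@H](Cc2ccccc2)NC(=O)[C@@H](Cc2ccccc2)NC(=O)[C@@H](CCCCNC(=O)OCc2ccc(Cl)cc2)NC(=O)[C@H](C(C)C)N(C)C1=O`) gives 7600 nM
Compound 2 (`CC(C)C[C@@H]1NC(=O)[C@H](Cc2ccccc2)NC(=O)[C@@H](Cc2ccccc2)N(C)C(=O)[C@@H](CCCCNC(=O)OCc2ccc(Cl)cc2)NC(=O)[C@H](C(C)C)NC1=O`) gives 2900 nM
Compound 3 (`CC(C)C[C@@H]1NC(=O)[C@@H]([C@H](OCc2ccccc2)c2ccccc2)NC(=O)[C@@H](Cc2ccccc2)NC(=O)[C@@H](CC(C)C)NC(=O)[C@H](C(C)C)N(C)C1=O`) gives 3200 nM

In a functional assay on HCT-116 cells (Homo sapiens) for cytotoxicity, read by hypoxanthine incorporation, with a stated time of 72 h (a lower number here means a stronger inhibitor, a higher number a weaker inhibitor), compound 3 gives 3200 nM and lies within the scatter of compound 2 but beyond the scatter below compound 1 in this small set. Compound 4 (`CC(C)C[C@@H]1NC(=O)[C@@H]([C@@H](OCc2ccccc2)c2ccccc2)NC(=O)[C@@H](Cc2ccccc2)NC(=O)[C@@H](CC(C)C)NC(=O)[C@H](C(C)C)N(C)C1=O`) differs from compound 3 in one place: the two compounds have the same atoms and bonds and differ only in configuration as drawn: 1 of 6 stereo elements differ; a stereocentre at a saturated chain carbon is drawn R in compound 3 and S in compound 4 (a stereocentre at a saturated chain carbon is drawn R in compound 3 and S in compound 4). Going by the values given here, no measured pair here isolates such a change, so its direction remains open. The expected change is a 1.4-fold higher number from compound 3 to compound 4 (0.15 log units; within the scatter) and this estimated step stays within the scatter. For compound 4 the estimated value is 4500 nM (expected range 1600 nM to 12000 nM).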

Compound 4, half-maximal inhibitory concentration: 8900 nM
Beside the measured number, compound 4's estimate is 2.0-fold (0.30 log units) below it, within the range that was stated.
By their numbers in this assay, from the lowest: compounds 2 and 3 (each within the scatter of the next); then compounds 1 and 4 (each within the scatter of the next).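

In this assay, going by these compounds alone, the drawn stereocentre at a saturated chain carbon, R in compound 3 and S in compound 4, gives a 2.8-fold higher number from compound 3 to compound 4 (0.44 log units; beyond the scatter), the only step that isolates one place. The position is therefore sensitive to configuration, with R giving the stronger inhibitor of this pair, though the step is modest. The step can be assigned to this stereocentre alone, because nothing else separates the pair: the fact that compounds 3 and 4 differ only in the configuration as drawn

The compounds shown leave open whether R remains preferred when the group on this carbon carries an amine or a carboxylic acid. They also do not show how this stereocentre behaves on the other cores in the series.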